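This account rests on a few compounds, and the source may have more. Where it says the series, first, only, none or still open, it means among the compounds named here.

Among the measured compounds shown here, in a functional assay for inhibition, with Homo sapiens as the target (on this read-out lower numbers stand for stronger inhibition and higher numbers for weaker inhibition), compound 1 `O=C(NC[C@H](NS(=O)(=O)c1ccccc1)C(=O)O)c1cc2cc(OCCC3CCNCC3)ccc2[nH]1` gives 8 nM, the lower of the two numbers measured so far. For the measured compounds named here, the only other measured compound, compound 2 `Cn1c(C(=O)NC[C@H](NS(=O)(=O)c2ccccc2)C(=O)O)cc2cc(OCCC3CCNCC3)ccc21`, gives 21 nM. Compound 3 `Nc1cc(COc2ccc3[nH]c(C(=O)NC[C@H](NS(=O)(=O)c4ccccc4)C(=O)O)cc3c2)ccn1` has yet to be measured. It differs from compound 1 in one place: 2-aminopyridin-4-yl in place of (piperidin-4-yl)methyl on a saturated chain carbon bound to an oxygen on an aromatic ring. Read one bond further out, 2-(piperidin-4-yl)ethoxy becomes (2-aminopyridin-4-yl)methoxy.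

Going by the values given here, only one measured step is available, a 2.6-fold higher number from compound 1 to compound 2 (0.42 log units; beyond the scatter). It puts methyl in place of hydrogen on an aromatic nitrogen, so it bears on the new change only indirectly. It shows that even a single methyl can move the number beyond the scatter in this assay. Both measured compounds carry the (piperidin-4-yl)methyl group, so the data do not test its replacement. Swapping a whole non-aromatic ring for an aromatic one is a larger change than that methyl, so a larger step than a 2.6-fold higher number from compound 1 to compound 2 (0.42 log units; beyond the scatter) is expected, toward a higher number. The expected step is a 6.3-fold higher number from compound 1 to compound 3 (0.80 log units; beyond the scatter), and this estimate is uncertain. For compound 3 the estimated value is 50 nM, with an expected range from 8 nM to 300 nM.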

Compound 3, half-maximal inhibitory concentration: 45 nM
For compound 3 the middle estimate is 1.1-fold (0.05 log units) above the measured one; the measured number falls inside the stated range.
By their numbers in this assay, from the lowest: compound 1; then compound 2; then compound 3.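

In this assay, among the compounds shown here, the position on a saturated chain carbon bound to an oxygen on an aromatic ring is tested for the first time, since compound 1 and compound 2 carry the same group there. Putting 2-aminopyridin-4-yl in place of (piperidin-4-yl)methyl gives a 5.6-fold higher number from compound 1 to compound 3 (0.75 log units; beyond the scatter), so the number rises, yet compound 3 still gives a measurable 45 nM after the non-aromatic ring is exchanged for an aromatic one. Nothing available here explains this rise.

This single swap changes the ring, adds an amino group and, read one bond further out, shortens the chain, so a plain pyridine ring without the amino group, or a (piperidin-4-yl)methoxy group with the piperidine ring kept on the shorter chain, would be needed to separate these changes. From the compounds shown here alone, it also remains open whether the methyl on the aromatic nitrogen, which gave a 2.6-fold higher number from compound 1 to compound 2 (0.42 log units; beyond the scatter) when added to compound 1, would shift the number by a similar amount if added to compound 3.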